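A few compounds are considered here, and "the series" means these few. Any claim that something is new, unique, unknown or untested is made for them only; others in the source may bear on it.

Among the compounds with values here, compound 3 `C=CCOc1ccc(Br)cc1C(=O)c1cccnc1` gives 59000 nM in a functional assay on PC-3 cells (Homo sapiens) for cytotoxicity, read by sulforhodamine B assay, with a stated time of 48 h (on this read-out higher numbers stand for weaker inhibition and lower numbers for stronger inhibition), the highest of the three numbers so far. Compound 2 `O=C(c1cccnc1)c1ccccc1O` gives 33400 nM in this assay, within the scatter of compound 3. Compound 1 `O=C(c1cccnc1)c1cc(F)ccc1O` gives 11800 nM, beyond the scatter below compound 3. Within the data shown here, the only step measured so far, a 2.8-fold higher number from compound 1 to compound 2 (0.45 log units; beyond the scatter), concerns the halogen and not the oxygen substituent, so no measured step bears directly on the change to compound 4 `O=C(c1cccnc1)c1cc(Br)ccc1O`, which is hydrogen in place of allyl on an oxygen on an aromatic ring. Compounds 1 and 2 both carry the hydroxy and sit at or below compound 3, so a step in the direction of a lower number is expected, a 4.5-fold lower number from compound 3 to compound 4 (0.66 log units; beyond the scatter), with compound 4 expected near compound 1 at 13000 nM, between 4000 nM and 40000 nM.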

Compound 4, half-maximal inhibitory concentration: 60200 nM
The estimate for compound 4 lay 4.6-fold (0.67 log units) below the measured number; measured number above the stated range.
By their numbers in this assay, from the lowest: compound 1; then compounds 2, 3 and 4 (each within the scatter of the next).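

Exchanging allyl for hydrogen on the oxygen on an aromatic ring leaves this assay unmoved in the bromo pair (a 1.0-fold higher number from compound 3 to compound 4 (0.01 log units; within the scatter)), so the hydroxy alone does not bring a low number here. On the aromatic carbon, bromo cannot be told from hydrogen (a 1.8-fold higher number from compound 2 to compound 4 (0.26 log units; within the scatter)), whereas fluoro separates from bromo (a 5.1-fold higher number from compound 1 to compound 4 (0.71 log units; beyond the scatter)); among these three compounds with the hydroxy, only the fluoro compound stands apart. No measurement at hand accounts for these results.

Open, going by these compounds, is whether allyloxy reads the same with fluoro on that carbon. A longer chain or a carboxylic acid on the oxygen also remains untested among the compounds shown.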